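A few compounds are considered here, and "the series" means these few. Any claim that something is new, unique, unknown or untested is made for them only; others in the source may bear on it.

Of the compounds shown here, three sharing one core have been measured in a functional assay on HepG2 cells (Homo sapiens) for cytotoxicity, read by MTT assay, with a stated time of 24 h; on this read-out lower numbers stand for stronger inhibition and higher numbers for weaker inhibition. Compound 1 `CC(=O)Nc1ccc(S(=O)(=O)N2C/C(=C\c3ccccc3F)C(=O)/C(=C/c3ccccc3F)C2)cc1` gives 5840 nM, compound 2 `CC(=O)Nc1ccc(S(=O)(=O)N2C/C(=C\c3cccc([N+](=O)[O-])c3)C(=O)/C(=C/c3ccccc3F)C2)cc1` gives 8800 nM, and compound 3 `COc1cc(/C=C2\CN(S(=O)(=O)c3ccc(NC(C)=O)cc3)C/C(=C\c3ccccc3F)C2=O)cc(OC)c1OC` gives 4750 nM. The steps from compound 3 to the other two lie within the scatter, so no order among the three can be read. The unmeasured compound 4 `COc1cc(/C=C2\CN(S(=O)(=O)c3ccc(NC(C)=O)cc3)C/C(=C\c3ccccc3F)C2=O)cc(OC)c1` differs from compound 3 in one place hydrogen in place of methoxy on an aromatic carbon, which turns 3,4,5-trimethoxyphenyl into 3,5-dimethoxyphenyl. Within the data shown here, no measured step makes exactly this change. The closest evidence comes from swaps of a whole aromatic group: a 1.2-fold lower number from compound 1 to compound 3 (0.09 log units; within the scatter), a 1.9-fold lower number from compound 2 to compound 3 (0.27 log units; within the scatter) and a 1.5-fold higher number from compound 1 to compound 2 (0.18 log units; within the scatter). All three stay within the scatter, so no step beyond the scatter is expected in this assay, in either direction. The expected step is a 1.1-fold higher number from compound 3 to compound 4 (0.02 log units; within the scatter). Compound 4 is estimated at 5000 nM, with an expected range from 2500 nM to 10000 nM.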

Compound 4, half-maximal inhibitory concentration: 6800 nM
The estimate for compound 4 lay 1.4-fold (0.13 log units) below the measured number; the measured number falls inside the stated range.
By their numbers in this assay, from the lowest: compounds 3, 1, 4 and 2 (each within the scatter of the next).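

Among these compounds, this is the first measured change of a single group on this aromatic ring rather than a swap of the whole aromatic group, and in this assay hydrogen in place of the methoxy gives a 1.4-fold higher number from compound 3 to compound 4 (0.16 log units; within the scatter). The new 3,5-dimethoxyphenyl compound also stays within the scatter of the other two, with a 1.3-fold lower number from compound 2 to compound 4 (0.11 log units; within the scatter) and a 1.2-fold higher number from compound 1 to compound 4 (0.07 log units; within the scatter), so in this small set the methoxy at this place, para to a large group, is not shown to matter for this read-out. Nothing measured here speaks to the reason behind these numbers.

The compounds shown leave open whether another group on this carbon, such as an amine, a carboxylic acid or a longer chain like butoxy, would move the number beyond the scatter. They also leave open what replacing the two remaining methoxy groups with hydrogen would do.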